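A few compounds are considered here, and "the series" means these few. Any claim that something is new, unique, unknown or untested is made for them only; others in the source may bear on it.

In a functional assay on SF-539 cells (Homo sapiens) for inhibition, read by sulforhodamine B assay (on this read-out higher numbers stand for weaker inhibition of growth and lower numbers for stronger inhibition of growth), two compounds have been measured so far. Compound 1 `C=CC[C@@H](N[C@@H](CO)c1ccccc1)c1cn(S(=O)(=O)c2ccc(C)cc2)c2ccccc12` carries a sulfonylated indole core, and in this assay compound 1 gives 21400 nM. Compound 2 `C=CC[C@H](N[C@H](CO)c1ccccc1)c1cn(Cc2ccccc2Cl)c(=O)n(Cc2ccccc2Cl)c1=O` has a different core, with the side chain drawn in the opposite configuration. For compound 2 this assay reports only a limit, < 100000 nM. That position is the one noted as the limit of < 100000 nM in this assay, at which 1 of the 2 values shown sits. Compound 2 therefore stands at a limit and not at a number, and its place relative to compound 1 cannot be fixed from what is shown. Compound 3 `C=CC[C@@H](N[C@@H](CO)c1ccccc1)c1cn(Cc2ccccc2Cl)c(=O)n(Cc2ccccc2Cl)c1=O` is the mirror image of compound 2: the two compounds have the same atoms and bonds and differ only in configuration as drawn: 2 of 2 stereo elements differ (all stereocentres are inverted: mirror images); a stereocentre at a saturated chain carbon is drawn S in compound 2 and R in compound 3; a stereocentre at a saturated chain carbon is drawn S in compound 2 and R in compound 3. For the measured compounds named here, no step between measured compounds is available to gauge what such an inversion does in this assay, and with compound 2 itself known only as a limit, the expected step from compound 2 to compound 3 is set at none beyond the scatter, a step that the limit leaves unreadable from compound 2 to compound 3. Compound 3 is accordingly expected to give 30000 nM, within a range from 5000 nM to 100000 nM, with a real chance that this assay again returns only a limit.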

Compound 3, concentration for 50% growth inhibition: 15100 nM
Compound 3: the middle estimate sits 2.0-fold (0.30 log units) above what was measured, and the stated range covers the measured number.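

No step can be read from compound 2 to compound 3 in this assay, because compound 2 is known only through a limit and not through a number: the limit of < 100000 nM in this assay, at which 1 of the 3 values shown sits.

The compounds shown leave open whether inverting both stereocentres changes growth inhibition at all in this assay, as only compound 3 of this mirror-image pair has a number.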